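This account rests on a few compounds, and the source may have more. Where it says the series, first, only, none or still open, it means among the compounds named here.

Compound 1 `COc1ccc(-c2nc3cc(Cl)c(Cl)cc3[nH]2)cc1` gives 30000 nM in an ADME assay on Vero cells (Chlorocebus sabaeus) for cytotoxicity (a lower number here means that less compound is tolerated, a higher number that more compound is tolerated), the lowest of the two numbers recorded in that setting. Within the data shown here, compound 3 `COc1ccc(-c2nc3cc(Cl)c(Cl)cc3[nH]2)c([N+](=O)[O-])c1` gives 80000 nM in this assay, and the step of a 2.7-fold higher number from compound 1 to compound 3 (0.43 log units; beyond the scatter) is the only measured step that bears on the case. Compound 2 `CCC(=O)Nc1ccc(-c2nc3cc(C(F)(F)F)ccc3n2C)cc1` shows in this assay only a limit, > 100000 nM. That value is the limit of > 100000 nM in this assay, at which 1 of the 3 values shown sits. Compound 4 `O=[N+]([O-])c1ccc(-c2nc3cc(Cl)c(Cl)cc3[nH]2)cc1` differs from compound 1 by nitro in place of methoxy on an aromatic carbon. Among the measured compounds shown here, the one measured step that introduced a nitro group raised the number modestly and beyond the scatter, so a modest rise of similar size is expected here. Compound 4 is therefore estimated at 50000 nM, within 20000 nM to 120000 nM, meaning an expected step of a 1.7-fold higher number from compound 1 to compound 4 (0.22 log units; within the scatter).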

Compound 4, half-maximal cytotoxic concentration: >= 100000 nM
Compound 4 ended at the assay's limit; the forecaster's own chance of this, stated with the estimate: 25%; at least 2.0-fold (0.30 log units) between middle value and limit.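

In this assay, nitro in place of methoxy on the aromatic carbon para to a large group gives an at least 3.3-fold higher number from compound 1 to compound 4 (0.52 log units; beyond the scatter). Compound 4 stands at a limit and not at a number: the limit of >= 100000 nM in this assay, at which 1 of the 4 values shown sits. Compound 3 keeps its methoxy, whereas compound 4 shows that the number also rises when methoxy itself leaves and nitro takes this position.

The compounds shown do not separate the loss of methoxy from the arrival of nitro, which a plain hydrogen at this position could do. They also leave open how an amine or a carboxylic acid would fare there.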